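From aryl amide to 1-carboxyethyl amide

The source may report more compounds than this note shows. Statements on the series, on what has been measured and on what is new or still open speak of the compounds shown alone.

In a functional assay on PC-3 cells (Homo sapiens) for antiproliferative activity, read by MTT assay, with a stated time of 48 h (a lower number here means a stronger inhibitor, a higher number a weaker inhibitor), the measured compounds gave these values
Compound 1 `CCN(CC)CCNC(=O)c1ccc(C(CC)(CC)c2ccc(OCCC(O)(CC)CC)c(C)c2)n1CC` gave 3350 nM
Compound 2 `CCn1c(C(=O)NCC#N)ccc1C(CC)(CC)c1ccc(OCCC(O)(CC)CC)c(C)c1` gave 17800 nM
Compound 3 `CCn1c(C(=O)Nc2cccc(C(F)(F)F)c2)ccc1C(CC)(CC)c1ccc(OCCC(O)(CC)CC)c(C)c1` gave 23800 nM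

Two steps place compound 3: one lies within the scatter (a 1.3-fold higher number from compound 2 to compound 3 (0.13 log units; within the scatter)) and one beyond it (a 7.1-fold higher number from compound 1 to compound 3 (0.85 log units; beyond the scatter)). Compound 4 `CCn1c(C(=O)NC(C)C(=O)O)ccc1C(CC)(CC)c1ccc(OCCC(O)(CC)CC)c(C)c1` has 1-carboxyethyl in place of 3-(trifluoromethyl)phenyl on an amide-type nitrogen. For the measured compounds named here, no measured step makes this exact exchange. The closest exchange replaces cyanomethyl with 3-(trifluoromethyl)phenyl and stayed within the scatter (a 1.3-fold higher number from compound 2 to compound 3 (0.13 log units; within the scatter)). The steps beyond the scatter both start from the 2-(diethylamino)ethyl group of compound 1 (a 5.3-fold higher number from compound 1 to compound 2 (0.73 log units; beyond the scatter)), and compound 4 lacks that group. No step beyond the scatter is therefore expected in this assay (a 1.1-fold lower number from compound 3 to compound 4 (0.03 log units; within the scatter)). The estimate for compound 4 is 22000 nM (expected range 8000 nM to 60000 nM).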

Compound 4, half-maximal inhibitory concentration: 11700 nM
Beside the measured number, compound 4's estimate is 1.9-fold (0.27 log units) above it; the range from low to high includes it.
By their numbers in this assay, from the lowest: compound 1; then compounds 4, 2 and 3 (each within the scatter of the next, the first and the last beyond it).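

In this assay, 1-carboxyethyl on the amide-type nitrogen separates from 3-(trifluoromethyl)phenyl by a step just beyond the scatter (a 2.0-fold lower number from compound 3 to compound 4 (0.31 log units; beyond the scatter)), which cyanomethyl did not do, yet 1-carboxyethyl stays within the scatter of cyanomethyl (a 1.5-fold lower number from compound 2 to compound 4 (0.18 log units; within the scatter)). The 2-(diethylamino)ethyl group of compound 1 still stands apart from this new group as well (a 3.5-fold higher number from compound 1 to compound 4 (0.54 log units; beyond the scatter)). Nothing given here accounts for these steps. From the compounds shown here alone, it remains open whether the diethylamino end alone drives that gap. A primary amine or a carboxylic acid on a longer chain at this nitrogen could test it.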